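Phenyl for tert-butyl on the benzyl arm of compound 2

The source may hold more compounds than are shown below. What is called first, only, known or untested is meant among the compounds shown, and "the series" means these compounds.

Three sulfonamides built on the same bis(trifluoromethyl)phenyl core have been tested in a functional assay on ASPC1 cells (Homo sapiens) for inhibition, read by MTT assay, with a stated time of 72 h; on this read-out higher numbers stand for weaker inhibition of growth and lower numbers for stronger inhibition of growth. Compound 1, `O=S(=O)(NCCCNCc1cccc2ccccc12)c1cc(C(F)(F)F)cc(C(F)(F)F)c1`, gives 21000 nM. Compound 2, `CC(C)(C)c1ccc(CNCCNS(=O)(=O)c2cc(C(F)(F)F)cc(C(F)(F)F)c2)cc1`, gives 14000 nM, which stands second highest of the three numbers and within the scatter of compound 1. Among the measured compounds shown here, compound 3, `O=S(=O)(NCCCCNCc1ccc(Br)cc1)c1cc(C(F)(F)F)cc(C(F)(F)F)c1`, gives 2900 nM, a number that lies beyond the scatter below compound 2; no single-point step connects it to either of the others, so only the two values themselves can be compared.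

Compound 4, `O=S(=O)(NCCNCc1ccc(-c2ccccc2)cc1)c1cc(C(F)(F)F)cc(C(F)(F)F)c1`, has not yet been measured in this assay. It differs from compound 2 by phenyl in place of tert-butyl on an aromatic carbon, the new group sitting on an aromatic carbon of a six-membered aromatic ring of carbon only, para to a large group. For the measured compounds named here, no measured pair shows what such a swap does here. The account therefore expects a step from compound 2 to compound 4 of a 1.6-fold lower number from compound 2 to compound 4 (0.19 log units; within the scatter), toward somewhat stronger inhibition but not clearly beyond the scatter. Compound 4 is estimated at 9000 nM, with a range from 3000 nM to 25000 nM.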

Compound 4, concentration for 50% growth inhibition: 2800 nM
Compound 4: the middle estimate sits 3.2-fold (0.51 log units) above what was measured; measured number below the stated range.
By their numbers in this assay, from the lowest: compounds 4 and 3 (each within the scatter of the next); then compounds 2 and 1 (each within the scatter of the next).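

Among the compounds shown here, the step gives the first single-change reading and shows that the aromatic carbon on the benzyl arm of compound 2 is sensitive to the group it carries. In this assay phenyl in place of tert-butyl gives a 5.0-fold lower number from compound 2 to compound 4 (0.70 log units; beyond the scatter) and so moves the result toward stronger inhibition of growth, with a group of 6 heavy atoms and one ring replacing one of 4 heavy atoms and no ring. Nothing available here accounts for this change.

From the compounds shown here alone, it remains open whether an amine, a carboxylic acid or a methoxy group on the same aromatic carbon would keep this stronger inhibition. For the compounds shown here, it is also open whether a longer chain in place of the one in compound 4 would strengthen or weaken it.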